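Adding a (Carboxymethyl)amino Group to a Quinoline Ketone

The compounds below may be only part of what the source reports. "The series", "measured", "known", "first", "only" and "open" are said of these compounds alone.

Of the compounds shown here, two have been measured in an assay for inhibition of 17-beta-hydroxysteroid dehydrogenase type 2 (Homo sapiens), read by HPLC, with a stated time of 10 min, tested at 1 uM; on this read-out lower numbers stand for less inhibition and higher numbers for more inhibition at the one concentration tested (going by the name of the read-out). Compound 1, `N#Cc1ccc2ccc(C(=O)c3ccc(F)c(O)c3)nc2c1`, gives 56% in this assay, and compound 2, `O=C(c1ccc(F)c(O)c1)c1ccc2ccccc2n1`, gives 76%. For the measured compounds named here, compound 2 therefore stands highest of the two numbers; the only step between them, a number 20 percentage points higher from compound 1 to compound 2 (beyond the scatter), was a modest rise when hydrogen replaced cyano on an aromatic carbon.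

Compound 3, `O=C(O)CNc1ccc2ccc(C(=O)c3ccc(F)c(O)c3)nc2c1`, differs from compound 2 in one place: (carboxymethyl)amino in place of hydrogen on an aromatic carbon. Going by the values given here, the single measured step bears on this change only loosely, since it also exchanged a group on an aromatic carbon of the shared core, and there the substituted compound 1 sat lower than the unsubstituted compound 2 by a modest margin. On that basis a modest fall in this assay is expected from compound 2 to compound 3, a number 18 percentage points lower from compound 2 to compound 3 (beyond the scatter), though with wide uncertainty because the entering group is unlike cyano. Compound 3 is thus estimated at 58%, within 30% to 85%.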

Compound 3, a percentage reported as inhibition, at one concentration (the size of the read-out at that concentration, not a potency): 63%
Compound 3: middle estimate off by 5 percentage points, on the low side; low and high end bracket the measured number.
By their numbers in this assay, from the lowest: compounds 1 and 3 (each within the scatter of the next); then compound 2.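

Adding (carboxymethyl)amino gives a number 13 percentage points lower from compound 2 to compound 3 (beyond the scatter) in this assay and so makes this the second group on this aromatic carbon to sit below hydrogen, a pattern that no compound shown goes against. Exchanging cyano for this group of 5 heavy atoms gives a number 7 percentage points higher from compound 1 to compound 3 (within the scatter) and so leaves the two substituted compounds indistinguishable in this test, even though the groups themselves are very different. No available evidence explains either step.

Still open, as far as these compounds go, is which part of the new group goes with the lower number: a simple amine or a carboxylic acid attached directly to this carbon would help separate the two. A longer chain ending in a carboxylic acid, or the same group on another carbon of the shared core, also remains to be placed against compound 2.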